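Swapping the five-membered ring on the core: compound 4

This account rests on a few compounds, and the source may have more. Where it says the series, first, only, none or still open, it means among the compounds named here.

Measured compounds:
compound 1, `O=C(/C=C/c1cn(-c2ccccc2)nc1-c1ccsc1)c1ccccc1`: 1900 nM
compound 2, `COc1ccc(OC)c(C(=O)/C=C/c2cn(-c3ccccc3)nc2-c2ccsc2)c1`: 400 nM
compound 3, `COc1ccc(C(=O)/C=C/c2cn(-c3ccccc3)nc2-c2ccsc2)c(OC)c1`: 9000 nM

In a functional assay on MCF7 cells (Homo sapiens) for inhibition, read by sulforhodamine B assay, with a stated time of 72 h (a lower number here means a stronger inhibitor, a higher number a weaker inhibitor), compound 1 stands second highest of the three numbers; compound 2 sits below it and compound 3 above it. The two steps from compound 1 both concern the aryl on the carbonyl carbon: a 4.8-fold lower number from compound 1 to compound 2 (0.68 log units; beyond the scatter) and a 4.7-fold higher number from compound 1 to compound 3 (0.68 log units; beyond the scatter), and between those two dimethoxy isomers lies a 23-fold higher number from compound 2 to compound 3 (1.35 log units; beyond the scatter).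

Compound 4, `O=C(/C=C/c1cn(-c2ccccc2)nc1-c1ccncc1)c1ccccc1`, changes a different place on the shared core: pyridin-4-yl in place of thiophen-3-yl on an aromatic carbon. Within the data shown here, none of the measured steps touches this ring, so the three compounds give no direct guide to its size or direction. With nothing to point either way, the expected step is a 1.3-fold higher number from compound 1 to compound 4 (0.12 log units; within the scatter), that is, no change beyond the scatter, with a wide range to allow for an unseen effect. Compound 4 is therefore estimated at 2500 nM in this assay, between 600 nM and 10000 nM.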

Compound 4, half-maximal inhibitory concentration: 3400 nM
Compound 4: middle estimate off by 1.4-fold (0.13 log units), on the low side; low and high end bracket the measured number.
By their numbers in this assay, from the lowest: compound 2; then compounds 1 and 4 (each within the scatter of the next); then compound 3.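

In this assay, among these compounds, pyridin-4-yl in place of thiophen-3-yl gives a 1.8-fold higher number from compound 1 to compound 4 (0.25 log units; within the scatter), so this is a first reading at a place on the shared core other than the aryl on the carbonyl carbon. Here a six-membered aromatic ring with a ring nitrogen and a five-membered aromatic ring with a sulfur cannot be told apart, whereas every step at the aryl on the carbonyl carbon lies beyond the scatter. Nothing measured here bears on the reason for this result.

From the compounds shown here alone, whether the two rings also stay alike when the carbonyl carbon bears 2,5-dimethoxyphenyl, as in compound 2, remains open. So does the effect at this position of a group of another kind, such as a morpholine or a simple methyl.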